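The source may report more compounds than this note shows. Statements on the series, on what has been measured and on what is new or still open speak of the compounds shown alone.

Compound 3, with the structure `N#Cc1cc2c(nc1N1CCC(C(=O)NS(=O)(=O)c3ccc(Cl)s3)CC1)COC2=O`, is the anchor of this comparison. In a functional assay (Platelet, plasma) for inhibition, with Homo sapiens as the target (on this read-out lower numbers stand for stronger inhibition and higher numbers for weaker inhibition), compound 3 gives 4470 nM, and that is the only plain number shown. Compound 2, with the structure `CC1OC(=O)c2cc(C#N)c(N3CCC(C(=O)NS(=O)(=O)c4ccc(Cl)s4)CC3)nc21`, carries a methyl on a saturated ring carbon where compound 3 carries hydrogen. In this assay compound 2 reaches only the limit of the assay, > 300000 nM, and not a number; this is the limit described as the limit of > 300000 nM in this assay, at which 1 of the 3 values shown sits. Going by the values given here, the single measured step is therefore an at least 67-fold lower number from compound 2 to compound 3 (1.82 log units; beyond the scatter). Compound 1, with the structure `N#Cc1cc2c(nc1N1CCC(C(=O)NS(=O)(=O)C(F)(F)c3ccccc3)CC1)COC2=O`, has no result in this assay, "not determined" (no result reported).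

Compound 4, with the structure `CC(c1ccccc1)S(=O)(=O)NC(=O)C1CCN(c2nc3c(cc2C#N)C(=O)OC3)CC1`, differs from compound 3 in one place: 1-phenylethyl in place of 5-chlorothiophen-2-yl on a sulfonyl sulfur. Among the compounds with values here, no measured step touches the group on the sulfonyl sulfur; the only measured step concerns the methyl on a saturated ring carbon, so it gives no guide here. Without a bearing step, the expectation for compound 4 is a change of a 1.3-fold higher number from compound 3 to compound 4 (0.13 log units; within the scatter) that stays within the usual scatter. Compound 4 is thus estimated at 6000 nM in this assay, within a range from 1500 nM to 30000 nM.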

Compound 4, half-maximal inhibitory concentration: 4160 nM
Estimate against measurement, compound 4: 1.4-fold (0.16 log units) above, within the range that was stated.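

In this assay, the group on the sulfonyl sulfur can be exchanged with only a 1.1-fold lower number from compound 3 to compound 4 (0.03 log units; within the scatter). Going by these compounds alone, this is the first measured step at this position, and it shows that a five-membered aromatic ring carrying chlorine and sulfur can give way to 1-phenylethyl, with its six-membered all-carbon aromatic ring, without a change beyond the scatter; the only earlier step, at a saturated ring carbon, was large. Nothing in the data shown accounts for this tolerance at the sulfonyl sulfur.

Steps involving compound 1 cannot be read, so the two groups of compound 3 and compound 4 are the only comparison at this position. Going by these compounds, whether an amine, a carboxylic acid or a longer alkyl chain on the sulfonyl sulfur would shift the number beyond the scatter remains open.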